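The compounds below may be only part of what the source reports. "The series", "measured", "known", "first", "only" and "open" are said of these compounds alone.

Compound 1 `CCOc1cc(NC(=O)CCCCC(=O)Nc2cc(-c3ccccc3)ccc2N)cc2c1OCC([N+](=O)[O-])=C2` and compound 2 `CCOc1cc(NC(=O)CCCCCCC(=O)Nc2cc(-c3ccccc3)ccc2N)cc2c1OCC([N+](=O)[O-])=C2` share a core whose difference is not broken down here. In a functional assay on PC-3 cells (Homo sapiens) for antiproliferative activity, read by MTT assay, with a stated time of 48 h (a higher number here means a weaker inhibitor of growth, a lower number a stronger inhibitor of growth), compound 1 gives 14600 nM, and compound 2 gives 10700 nM. Compound 3 `CCOc1cc(NC(=O)CCCCCCC(=O)Nc2cc(-c3ccc(C)s3)ccc2N)cc2c1OCC([N+](=O)[O-])=C2` carries the change 5-methylthiophen-2-yl in place of phenyl on an aromatic carbon on the core of compound 2; in this assay compound 3 gives 6360 nM, a step of a 1.7-fold lower number from compound 2 to compound 3 (0.23 log units; within the scatter). Compound 4 `CCOc1cc(NC(=O)CCCCC(=O)Nc2cc(-c3ccc(C)s3)ccc2N)cc2c1OCC([N+](=O)[O-])=C2` carries the same change on the core of compound 1, namely (5-methylthiophen-2-yl in place of phenyl on an aromatic carbon). Because the step of a 1.7-fold lower number from compound 2 to compound 3 (0.23 log units; within the scatter) from compound 2 to compound 3 stayed within the scatter, the step from compound 1 to compound 4 in this assay is expected to be of similar size, a 1.7-fold lower number from compound 1 to compound 4 (0.23 log units; within the scatter). For compound 4 in this assay the estimate is therefore 8600 nM, with a range from 4300 nM to 17000 nM.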

Compound 4, concentration for 50% growth inhibition: 13500 nM
Beside the measured number, compound 4's estimate is 1.6-fold (0.20 log units) below it; measured number inside the range.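

In this assay, placing 5-methylthiophen-2-yl where phenyl stood on the core of compound 1 gives a 1.1-fold lower number from compound 1 to compound 4 (0.03 log units; within the scatter). The two cores do not separate on this change: the same change on two cores in this assay, a 1.7-fold lower number (0.23 log units; within the scatter) from compound 2 to compound 3 and a 1.1-fold lower number (0.03 log units; within the scatter) from compound 1 to compound 4, 1.6-fold (0.19 log units) apart, within the scatter of two such steps

This shows that the change produced no step beyond the scatter on either of these two cores, but it does not show that the change has a real effect on growth inhibition, or that the same would hold on any other core. The compounds shown leave open whether a plain thiophene or a pyridine ring at this place would give a step beyond the scatter. They also leave open how a longer chain would behave with either of these two groups.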